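Hydroxy on the benzylidene arm: expected tolerance in liver cells

This account rests on a few compounds, and the source may have more. Where it says the series, first, only, none or still open, it means among the compounds named here.

Measured compounds:
Compound 1, `Nc1sc2c(c1-c1nc3cc(Cl)ccc3s1)CCCC2`, 93.7 ug/mL
Compound 2, `C(=N/c1sc2c(c1-c1nc3ccccc3s1)CCCC2)\c1ccccc1`, 308 ug/mL
Compound 3, `COc1cc(/C=N/c2sc3c(c2-c2nc4ccccc4s2)CCCC3)cc(OC)c1OC`, 301 ug/mL

All three compounds were tested in an ADME assay on HepG2 cells (Homo sapiens) for cytotoxicity, read by MTT assay, with a stated time of 72 h; a higher number here means that more compound is tolerated, a lower number that less compound is tolerated. Compound 2 carries a benzylidene group on the amine of the shared core and gives the highest of the three numbers, 308 ug/mL. Compound 3, whose benzylidene ring carries three methoxy groups, gives 301 ug/mL, a value that sits within the usual scatter of compound 2, so the two cannot be told apart. Compound 1, which keeps a free amine and a chlorine on the other ring system, gives 93.7 ug/mL, a number well below the other two and beyond the scatter. Compound 1 differs from compound 2 in more than one place, so these two values show only that they lie apart.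

The unmeasured compound 4, `Oc1ccccc1/C=N/c1sc2c(c1-c1nc3ccccc3s1)CCCC2`, comes from compound 2 by a single change: hydroxy in place of hydrogen on an aromatic carbon. Among the compounds with values here, no measured pair shows this exact change. The closest guide is compound 3, whose substituted benzylidene ring gives 301 ug/mL alongside compound 2 at 308 ug/mL, with no difference beyond the scatter. On that basis the step is expected to be small in this assay, within the scatter, in no clear direction: a 1.1-fold lower number from compound 2 to compound 4 (0.04 log units; within the scatter). Compound 4 is therefore estimated at 280 ug/mL, with a likely range from 150 ug/mL to 520 ug/mL.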

Compound 4, half-maximal cytotoxic concentration: 114 ug/mL
Beside the measured number, compound 4's estimate is 2.5-fold (0.39 log units) above it; the measured number lies below the stated range.
By their numbers in this assay, from the lowest: compounds 1 and 4 (each within the scatter of the next); then compounds 3 and 2 (each within the scatter of the next).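

Within the data shown here, a move from phenyl to 2-hydroxyphenyl brings a 2.7-fold lower number from compound 2 to compound 4 (0.43 log units; beyond the scatter) in this assay and is the first change in this set that can be read at a single place. Compound 3 could not show this, since its ring carries three methoxy groups at once and so differs from compound 2 in more than one place. The new step shows that the benzylidene ring does not accept every change without consequence: one hydroxy in place of hydrogen, on an aromatic carbon ortho to a large group, is enough to move the number beyond the usual scatter of repeats, toward less compound being tolerated. Nothing measured here gives a reason for this step.

The compounds shown leave open whether the step belongs to hydroxy itself, since no other single group, such as an amine, a fluorine or a lone methoxy, appears at this same place. They also leave open whether hydroxy on a different carbon of the same ring would give a similar number.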